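A few compounds are considered here, and "the series" means these few. Any claim that something is new, unique, unknown or untested is made for them only; others in the source may bear on it.

Three close relatives share one core and differ in the aryl group on the saturated chain carbon. In an ADME assay on MDBK cells (Bos taurus) for cytotoxicity (a higher number here means that more compound is tolerated, a lower number that less compound is tolerated), compound 1 (`Cc1ccccc1Cn1ccc2nc(-c3ccccc3)nc-2c1`) gives > 100000 nM as a limit of the assay and not a number. Compound 2 (`Fc1cccc(Cn2ccc3nc(-c4ccccc4)nc-3c2)c1`) also gives only a limit, > 100000 nM in this case. Compound 3 (`Clc1ccc(Cn2ccc3nc(-c4ccccc4)nc-3c2)cc1`) likewise gives only a limit, > 100000 nM here. Compound 3 therefore stands with the other two at the limit of > 100000 nM in this assay, at which 3 of the 3 values shown sit, and cannot be ranked against them.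

Compound 4 (`c1ccc(-c2ccc(Cn3ccc4nc(-c5ccccc5)nc-4c3)cc2)cc1`) carries phenyl in place of chloro on an aromatic carbon, para to a large group (phenyl in place of chloro on an aromatic carbon). Going by the values given here, three measured steps bear on this change, since each swaps the substituted phenyl group: a step that the two limits leave unreadable from compound 1 to compound 2 then a step that the two limits leave unreadable from compound 1 to compound 3 and finally a step that the two limits leave unreadable from compound 2 to compound 3 with no size to be taken from any of them. Among the compounds with values here, they show only that all three groups leave the compounds at the limit, and none of the three is as large as the new group. In this assay no step beyond the usual scatter is therefore expected, and the estimate is a number no higher from compound 3 to compound 4 (the limit leaves the size open) as a working figure. Compound 4 is estimated at 100000 nM with an expected range from 40000 nM to 200000 nM and a limit of the assay is expected again.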

Compound 4, half-maximal cytotoxic concentration: 18000 nM
Estimate against measurement, compound 4: 5.6-fold (0.74 log units) above; the measured number lies below the stated range.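

In this assay, phenyl in place of chloro on an aromatic carbon, para to a large group, gives an at least 5.5-fold lower number from compound 3 to compound 4 (0.74 log units; beyond the scatter), so less compound is tolerated with phenyl at this position than with chloro. The earlier steps shown here among compounds 1, 2 and 3 could not be read, which left open whether a change on this aryl group could matter at all in this assay; this step shows that it can, with a change that brings in six heavy atoms and a ring where one chlorine atom stood. Going by these compounds alone, compound 4 is also the first compound here to give a number instead of a limit of the assay: the limit of > 100000 nM in this assay, at which 3 of the 4 values shown sit.

On these data alone, the full size of the step stays open, as the value for compound 3 is only a limit, and one pair of compounds cannot separate the effect of the ring from that of the larger number of atoms. A saturated ring such as cyclohexyl, a pyridine ring or a smaller group such as methoxy at the same position would help to tell how far the lower number is tied to phenyl itself.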